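The source may hold more compounds than are shown below. What is called first, only, known or untested is meant among the compounds shown, and "the series" means these compounds.

Working notes on the rhodanine-acetic-acid series, substituted benzyl arm.

Compound 1 `O=C(O)CN1C(=O)/C(=C/c2nc3ccccc3n2Cc2ccc(Br)cc2F)SC1=S` is the reference point. In a functional assay on HL-60 cells (Homo sapiens) for cytotoxicity, read by MTT assay, with a stated time of 48 h (a higher number here means a weaker inhibitor, a lower number a stronger inhibitor), compound 1 gives 6420 nM, the second highest of the three numbers in hand. Its nearest neighbour is compound 3 `O=C(O)CN1C(=O)/C(=C/c2nc3ccccc3n2Cc2cccc(F)c2)SC1=S`, which gives 7210 nM; the step of a 1.1-fold higher number from compound 1 to compound 3 (0.05 log units; within the scatter) lies within the scatter. Its furthest neighbour is compound 2 `O=C(O)CN1C(=O)/C(=C/c2nc3ccccc3n2Cc2ccccc2F)SC1=S`, which gives 210 nM; the step of a 31-fold lower number from compound 1 to compound 2 (1.49 log units; beyond the scatter) is large, and so is a 34-fold higher number from compound 2 to compound 3 (1.54 log units; beyond the scatter).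

The next compound, compound 4 `COc1cc(Cn2c(/C=C3\SC(=S)N(CC(=O)O)C3=O)nc3ccccc32)cc(OC)c1`, changes the same place as the earlier aryl swaps: 3,5-dimethoxyphenyl in place of 4-bromo-2-fluorophenyl on a saturated chain carbon bound to an aromatic nitrogen

Of the measured steps, the one that bears on this most directly is a 1.1-fold higher number from compound 1 to compound 3 (0.05 log units; within the scatter), where the whole aryl on that saturated chain carbon was exchanged and the number barely moved. For the measured compounds named here, the only low number in the set, compound 2, carries 2-fluorophenyl; the 3,5-dimethoxyphenyl of compound 4 has no fluorine at all and is in that respect closer to compound 3 than to compound 2. The expectation is therefore a step of about a 1.3-fold higher number from compound 1 to compound 4 (0.12 log units; within the scatter) in this assay, essentially none beyond the scatter, with the risk leaning toward a higher number. Compound 4 is expected to give roughly 8500 nM, within the range 2500 nM to 30000 nM.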

Compound 4, half-maximal inhibitory concentration: 1410 nM
Estimate against measurement, compound 4: 6.0-fold (0.78 log units) above; measured number outside the range, below it.
By their numbers in this assay, from the lowest: compound 2; then compound 4; then compounds 1 and 3 (each within the scatter of the next).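

In this assay the aryl on the saturated chain carbon bound to an aromatic nitrogen now shows a third level, not just one low number against a flat remainder: a 4.6-fold lower number from compound 1 to compound 4 (0.66 log units; beyond the scatter) and a 5.1-fold lower number from compound 3 to compound 4 (0.71 log units; beyond the scatter) are both beyond the scatter, and so is a 6.7-fold higher number from compound 2 to compound 4 (0.83 log units; beyond the scatter) in the opposite direction. Fluorine on this aryl does not sort the series, since 3,5-dimethoxyphenyl has none and compound 4 still stands clear of compounds 1 and 3, both of which carry fluorine, while compound 2, also fluorinated, stays lowest. Nothing at hand gives a reason for these differences.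

As far as these compounds go, whether a single methoxy group on the phenyl gives a number like that of compound 4, or both are needed, remains open. So does whether a hydroxy group or an amine in place of the methoxy groups would fall nearer compound 2 or nearer compounds 1 and 3.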